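Adding a Chloro Group to the Sulfonyl Ring

The source may report more compounds than this note shows. Statements on the series, on what has been measured and on what is new or still open speak of the compounds shown alone.

Of the compounds shown here, three have been measured in a functional assay on trachea (Rattus norvegicus, strain Wistar), with a stated time of 15 min; a lower number here means that less compound is needed, a higher number that more compound is needed for the effect. Compound 1 `COc1ccc(Br)cc1C(C)NC(=O)N(C)S(=O)(=O)c1ccccc1` gives 8400 nM. Compound 2 `COc1ccc(OC)c(CNC(=O)N(C)S(=O)(=O)c2ccccc2)c1` gives 18500 nM, and compound 3 `COc1ccc(Cl)cc1C(C)NC(=O)N(C)S(=O)(=O)c1ccccc1` gives 1700 nM. Among these three numbers compound 1 stands second highest: compound 2 needs more compound than compound 1, and compound 3 needs less. Among the measured compounds shown here, the only single-point comparison so far is a 4.9-fold lower number from compound 1 to compound 3 (0.69 log units; beyond the scatter), a change on the ring that carries the methoxy group.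

Compound 4 `COc1ccc(Br)cc1C(C)NC(=O)N(C)S(=O)(=O)c1ccc(Cl)cc1` differs from compound 1 in one place: chloro in place of hydrogen on an aromatic carbon. For the measured compounds named here, this change sits on the ring attached to the sulfonyl group, not on the ring where the bromo-to-chloro step was seen, so no measured step bears directly on it; the step from compound 1 to compound 3 tells only that a halogen swap elsewhere in the molecule can move this assay by a modest amount. With nothing to point in either direction, the expectation for compound 4 is a number close to that of compound 1, with a change that is expected to be no larger than a 1.3-fold lower number from compound 1 to compound 4 (0.11 log units; within the scatter). Compound 4 is therefore estimated at 6500 nM, within a range from 2000 nM to 20000 nM.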

Compound 4, half-maximal effective concentration: 39300 nM
Compound 4: middle estimate off by 6.0-fold (0.78 log units), on the low side; the measured number lies above the stated range.
By their numbers in this assay, from the lowest: compound 3; then compound 1; then compound 2; then compound 4.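

Placing a chloro group in place of hydrogen on the ring attached to the sulfonyl group gives a 4.7-fold higher number from compound 1 to compound 4 (0.67 log units; beyond the scatter) in this assay, so more compound is needed for the effect after adding just one chlorine atom, para to a large group. This ring is therefore not a place where a change leaves the number untouched, and the direction here is opposite to that of a 4.9-fold lower number from compound 1 to compound 3 (0.69 log units; beyond the scatter), where chloro replaces bromo on the ring that carries the methoxy group, so the presence of chlorine alone does not decide which way the number moves; what counts is where it stands and what it replaces. The data shown offer no measurement that explains this rise.

As far as these compounds go, whether the higher number is specific to chloro stays open, as a fluoro, a methyl or a nitrile at the same place could give a different result, and it is also unknown whether any group here could give a lower number than hydrogen. From the compounds shown here alone, it is equally open whether the phenyl to 4-chlorophenyl change would have a similar effect when the other ring carries chloro instead of bromo, as in compound 3.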